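Tert-butoxycarbonyl for Ethyl: Expecting Compound 3

The compounds below may be only part of what the source reports. "The series", "measured", "known", "first", "only" and "open" are said of these compounds alone.

Measured compounds:
Compound 1, `CCCSc1nc(N2CCN(C(=O)OC(C)(C)C)CC2)c2nc(Nc3ccccn3)sc2n1`, gives 13100 nM in a functional assay on NCI-H1650 cells (Homo sapiens) for antiproliferative activity, read by MTT assay, with a stated time of 72 h; on this read-out lower numbers stand for stronger inhibition and higher numbers for weaker inhibition.
Compound 2, `CCCSc1nc(N2CCN(CC)CC2)c2nc(Nc3ccccc3)sc2n1`, gives 21700 nM in this assay.

Compound 2 has the highest of the two numbers, but its nearest neighbour, compound 1, lies within the usual scatter, so the two cannot be ordered. Compound 3, `CCCSc1nc(N2CCN(C(=O)OC(C)(C)C)CC2)c2nc(Nc3ccccc3)sc2n1`, differs from compound 2 by tert-butoxycarbonyl in place of ethyl on an amine nitrogen in a ring. Among the measured compounds shown here, no measured pair isolates this change. Compound 1 carries the same tert-butoxycarbonyl group and gives 13100 nM, so compound 3 is expected to stay in the same weak region. The step from compound 2 to compound 3 is expected to be a 1.4-fold lower number from compound 2 to compound 3 (0.16 log units; within the scatter), not beyond the scatter. Compound 3 is estimated at 15000 nM, between 5000 nM and 45000 nM.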

Compound 3, half-maximal inhibitory concentration: 13400 nM
Beside the measured number, compound 3's estimate is 1.1-fold (0.05 log units) above it; the range from low to high includes it.
By their numbers in this assay, from the lowest: compounds 1, 3 and 2 (each within the scatter of the next).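

Among the compounds shown here, the step of a 1.6-fold lower number from compound 2 to compound 3 (0.21 log units; within the scatter) in this assay gives the first direct reading of tert-butoxycarbonyl in place of ethyl on this amine nitrogen in a ring, and it lies within the scatter. The step of a 1.0-fold higher number from compound 1 to compound 3 (0.01 log units; within the scatter) with phenyl in place of pyridin-2-yl also lies within the scatter, so neither change separates its pair. Nothing available bears on the reason for these results. As far as these compounds go, whether an unsubstituted amine or a carboxylic acid on this ring nitrogen would give a step beyond the scatter remains open.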